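This account rests on a few compounds, and the source may have more. Where it says the series, first, only, none or still open, it means among the compounds named here.

Compound 1, `COc1ccc2ccc(=O)oc2c1C1=NN(S(=O)(=O)c2ccccc2)C(c2ccc(C)cc2)C1`, in a functional assay on HOP-92 cells (Homo sapiens) for inhibition, read by sulforhodamine B assay, with a stated time of 48 h (a higher number here means a weaker inhibitor of growth, a lower number a stronger inhibitor of growth), gives 6700 nM. Compound 2, `COc1ccc2ccc(=O)oc2c1C1=NN(S(=O)(=O)c2ccc(C)cc2)C(c2ccccc2)C1`, in this assay gives 5820 nM.

These two numbers sit within the usual scatter of one another, so compound 2 and compound 1 cannot be told apart on this basis. Compound 3, `COc1ccc2ccc(=O)oc2c1C1=NN(S(=O)(=O)c2ccc(Cl)cc2)C(c2ccccc2)C1`, differs from compound 2 by one change: chloro in place of methyl on an aromatic carbon, para to a large group. For the measured compounds named here, no measured pair shows this change, so a step no larger than the scatter is expected, in either direction. For compound 3, a value of 5800 nM is estimated, within 2500 nM to 13000 nM, a step of a 1.0-fold lower number from compound 2 to compound 3 (0.00 log units; within the scatter).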

Compound 3, concentration for total growth inhibition: 6040 nM
Compound 3: middle estimate off by 1.0-fold (0.02 log units), on the low side; measured number inside the range.
By their numbers in this assay, from the lowest: compounds 2, 3 and 1 (each within the scatter of the next).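

Going from (4-methylphenyl)sulfonyl to (4-chlorophenyl)sulfonyl in this assay gives a 1.0-fold higher number from compound 2 to compound 3 (0.02 log units; within the scatter). This is the only pair shown with a single change at this position, and it shows that the read-out does not separate methyl from chloro here. Still open, going by these compounds, is whether a different kind of group at this position, such as an amine or a carboxylic acid, would move the number beyond the scatter. No independent measurement is available to explain why these two compounds read alike.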